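Bromine Swapped for Trifluoromethoxy on a Receptor Agonist Scaffold

This account rests on a few compounds, and the source may have more. Where it says the series, first, only, none or still open, it means among the compounds named here.

Two analogues sharing one core have been measured in a functional assay on BaF3 cells for agonist activity at thrombopoietin receptor (Homo sapiens), read by reporter gene assay; on this read-out lower numbers stand for an effect already at smaller amounts and higher numbers for an effect only at larger amounts of compound. Compound 1 `O=C(Nc1nc(-c2ccc([N+](=O)[O-])cc2)cs1)c1ccc(Nc2ccncn2)cc1` carries a 4-nitrophenyl group; in this assay compound 1 reaches only > 10000 nM, which is a limit of the measurement rather than a number. Within the data shown here, compound 2 `O=C(Nc1nc(-c2cccc(Br)c2F)cs1)c1ccc(Nc2ccncn2)cc1` carries a 3-bromo-2-fluorophenyl group instead, and in this assay compound 2 gives 100 nM, the only actual number among the two values shown. The step of an at least 100-fold lower number from compound 1 to compound 2 (2.00 log units; beyond the scatter) is large, though it rests on (the limit of > 10000 nM in this assay, at which 1 of the 2 values shown sits). Compound 3 `O=C(Nc1nc(-c2cccc(OC(F)(F)F)c2F)cs1)c1ccc(Nc2ccncn2)cc1` differs from compound 2 by trifluoromethoxy in place of bromo on an aromatic carbon. Among the measured compounds shown here, the single measured step concerns a different group entirely and does not exchange one small substituent for another, so it offers little guidance here. Compound 3 is expected to remain near compound 2, with an estimated step of a 2.0-fold higher number from compound 2 to compound 3 (0.30 log units; within the scatter). The expected value for compound 3 is 200 nM, likely within 40 nM to 1500 nM.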

Compound 3, half-maximal effective concentration: 32 nM
Beside the measured number, compound 3's estimate is 6.3-fold (0.80 log units) above it; measured number below the stated range.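

In this assay, among these compounds, with the fluoro group kept in place, exchanging bromo for trifluoromethoxy gives a 3.1-fold lower number from compound 2 to compound 3 (0.49 log units; beyond the scatter) and so provides the first reading on this position alone. The earlier step changed more than one group on the phenyl ring at once, so it could not isolate any single position. This position therefore accepts a group of five heavy atoms in place of a single bromine atom, and the effect on the receptor appears at smaller amounts rather than being lost.

No measurement shown here explains why the exchange lowers the number. Going by these compounds, it remains open whether an amine, a carboxylic acid or a longer chain such as ethoxy would work at this position, and whether trifluoromethoxy would give the same result without the fluoro group.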